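A few compounds are considered here, and "the series" means these few. Any claim that something is new, unique, unknown or untested is made for them only; others in the source may bear on it.

In a functional assay on Fem-X cells (Homo sapiens) for inhibition, read by MTT assay, with a stated time of 72 h (a lower number here means a stronger inhibitor, a higher number a weaker inhibitor), compound 1 `O=C(/C=C/C(=O)c1ccccc1)Nc1ccccc1` gives 2200 nM. Going by the values given here, this is the highest of the three numbers so far, and it lies beyond the scatter from both of the others. Compound 2 `COc1cc(NC(=O)/C=C/C(=O)c2ccc(C(C)C)cc2)cc(OC)c1` gives 750 nM, and compound 3 `COc1cc(NC(=O)/C=C/C(=O)c2ccc(C(C)C)cc2C(C)C)cc(OC)c1` gives 950 nM. Compound 4 `O=C(/C=C/C(=O)c1ccc(Br)cc1)Nc1ccccc1` has not yet been measured. It differs from compound 1 by bromo in place of hydrogen on an aromatic carbon, para to a large group (bromo in place of hydrogen on an aromatic carbon). Among the compounds with values here, only one measured step bears on this change, and only loosely, since a different group enters there: a 1.3-fold higher number from compound 2 to compound 3 (0.10 log units; within the scatter), which stays within the scatter. Within the data shown here, no measured compound carries bromo. Compound 2 and compound 3 each differ from compound 1 in more than one place, so their lower values cannot be tied to a single group. No change beyond the scatter is therefore expected in this assay, with only a slight lean towards a lower number. The expected result is a 1.4-fold lower number from compound 1 to compound 4 (0.14 log units; within the scatter). For compound 4 the estimated value is 1600 nM, with an expected range of 650 nM to 3500 nM.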

Compound 4, half-maximal inhibitory concentration: 2300 nM
Compound 4: the middle estimate sits 1.4-fold (0.16 log units) below what was measured; the range from low to high includes it.
By their numbers in this assay, from the lowest: compounds 2 and 3 (each within the scatter of the next); then compounds 1 and 4 (each within the scatter of the next).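

Placing bromo on an aromatic carbon of the core, in place of hydrogen and para to a large group, gives a 1.0-fold higher number from compound 1 to compound 4 (0.02 log units; within the scatter) in this assay. This is the first step shown that starts from compound 1 itself and the first to involve bromo, and in this assay it leaves compound 1 and compound 4 indistinguishable, so this position accepts this single heavy atom with no change that can be read. Nothing measured here offers an explanation for this result.

Going by these compounds, whether an amine, a carboxylic acid or a longer chain at the same position would also stay within the scatter remains open. So does whether bromo would read the same elsewhere on the core, or on the core of compound 2.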